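The compounds below may be only part of what the source reports. "The series", "measured", "known", "first", "only" and "open" are said of these compounds alone.

Compound 1 `COC(=O)[C@@]1(C)CC[C@@H]2C3=C1CC[C@@H](C)[C@]3(C)Cc1c2[nH]c2ccc(C)cc12`: 19000 nM
Compound 2 `COC(=O)[C@@]1(C)CC[C@@H]2C3=C1CC[C@@H](C)[C@]3(C)Cc1c2[nH]c2ccc(Br)cc12`: 22000 nM
Compound 3 `COC(=O)[C@@]1(C)CC[C@@H]2C3=C1CC[C@@H](C)[C@]3(C)C[C@@H]1c3cccc(C)c3N[C@H]21`: 43000 nM

All three were run in a functional assay on WiDr cells (Homo sapiens) for inhibition, read by sulforhodamine B assay, with a stated time of 48 h; a higher number here means a weaker inhibitor of growth, a lower number a stronger inhibitor of growth. Compound 1 and compound 2 share one core; the change between them is bromo in place of methyl on an aromatic carbon, and it gave a 1.2-fold higher number from compound 1 to compound 2 (0.06 log units; within the scatter). Compound 3 has a different core; the difference between the core of compound 1 and that of compound 3 is not broken down here. The value of compound 3 differs from that of compound 1 beyond the scatter, while compound 3 and compound 2 lie within the scatter of each other, so the whole set is narrow.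

Compound 4 `COC(=O)[C@@]1(C)CC[C@@H]2C3=C1CC[C@@H](C)[C@]3(C)C[C@@H]1c3cccc(Br)c3N[C@H]21` has not been measured. It differs from compound 3 by bromo in place of methyl on an aromatic carbon. This is the same kind of change as from compound 1 to compound 2, not the same: there the place is meta to a fused ring and para to a fused ring, here it is ortho to a fused ring and meta to a fused ring. Among the measured compounds shown here, only one earlier example of bromo in place of methyl on an aromatic carbon exists here, and it stayed within the scatter.

The expectation for compound 4 in this assay rests on compound 3 at 43000 nM and on the step of a 1.2-fold higher number from compound 1 to compound 2 (0.06 log units; within the scatter). For compound 4 a step of about a 1.1-fold higher number from compound 3 to compound 4 (0.05 log units; within the scatter) is expected, with wide room either way. The estimate for compound 4 is 48000 nM, expected to fall between 22000 nM and 100000 nM.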

Compound 4, concentration for 50% growth inhibition: 54000 nM
For compound 4 the middle estimate is 1.1-fold (0.05 log units) below the measured one; measured number inside the range.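

In this assay, bromo in place of methyl on an aromatic carbon gave a 1.3-fold higher number from compound 3 to compound 4 (0.10 log units; within the scatter), and set beside the earlier example the change reads alike on both cores: the same change on two cores in this assay, a 1.2-fold higher number (0.06 log units; within the scatter) from compound 1 to compound 2 and a 1.3-fold higher number (0.10 log units; within the scatter) from compound 3 to compound 4, 1.1-fold (0.04 log units) apart, within the scatter of two such steps

Within these two pairs, then, the change carries from the core of compound 1 to the core of compound 3 with no step that stands out from the scatter, although on compound 4 the place is ortho to a fused ring and meta to a fused ring. Among the compounds shown here, this shows only that neither core separates methyl from bromo at these places; it fixes no order between the two groups, and two such small steps say nothing about how a change with a larger step would carry from one core to the other.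

Open, going by these compounds, is whether a group of another kind on this aromatic ring, such as an amine or a longer chain, would move the number beyond the scatter in this assay. Also open, on these data alone, is what a carboxylic acid or an amide in place of the methyl ester, which all four compounds share, would do to growth inhibition on either core.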